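Moving the Fluorine Around the Ring: Compound 4

The compounds below may be only part of what the source reports. "The series", "measured", "known", "first", "only" and "open" are said of these compounds alone.

For the measured compounds named here, compound 1 `Cc1cc(NC(=O)Nc2ccc(F)cc2)c2ccccc2n1` is the most soluble of the three compounds measured so far in a physicochemical assay for solubility, at pH 7.4 (a higher number here means a more soluble compound, a lower number a less soluble compound), where compound 1 gives 3700 nM. Its nearest neighbour is compound 2 `Cc1cc(NC(=O)Nc2ccc(C(N)=O)cc2)c2ccccc2n1`, which in this assay gives 900 nM, a step of a 4.1-fold lower number from compound 1 to compound 2 (0.61 log units; beyond the scatter). Furthest away is compound 3 `Cc1cc(NC(=O)Nc2ccc(C(F)(F)F)cc2)c2ccccc2n1`, which gives 100 nM, a step of a 37-fold lower number from compound 1 to compound 3 (1.57 log units; beyond the scatter). Between these two, the step is a 9.0-fold lower number from compound 2 to compound 3 (0.95 log units; beyond the scatter).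

Compound 4 `Cc1cc(NC(=O)Nc2cccc(F)c2)c2ccccc2n1` has not yet been measured. It differs from compound 1 only in the position of one atom: 3-fluorophenyl in place of 4-fluorophenyl on an amide-type nitrogen. The three measured steps all swap one group for a different group at the same place on the ring, and their sizes range from modest to large. Going by the values given here, none of them moves a group without changing its identity, so no measured step bears directly on the change from compound 1 to compound 4. The atoms and groups present stay exactly the same, and only their arrangement shifts, which gives no firm ground for a step in either direction.

Compound 4 is therefore expected to stay close to compound 1, with an estimated step of a 1.2-fold higher number from compound 1 to compound 4 (0.09 log units; within the scatter), and an estimated value of 4500 nM, in a range from 2000 nM to 10000 nM.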

Compound 4, solubility: 100 nM
Beside the measured number, compound 4's estimate is 45-fold (1.65 log units) above it; the measured number lies below the stated range.
By their numbers in this assay, from the lowest: compounds 3 and 4 (each within the scatter of the next); then compound 2; then compound 1.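

In this assay, moving the fluorine while keeping every atom gives a step of a 37-fold lower number from compound 1 to compound 4 (1.57 log units; beyond the scatter), so at this place on the amide-type nitrogen the arrangement of the ring counts, not only which group it carries. That step matches a 37-fold lower number from compound 1 to compound 3 (1.57 log units; beyond the scatter), where trifluoromethyl replaces fluoro, so among these compounds a change of position alone goes as far as the largest change of group. No measurement is available that would explain why the 3-fluorophenyl and 4-fluorophenyl compounds stand so far apart.

The compounds shown leave open whether moving a different group in the same way, such as the carbamoyl of compound 2 or the trifluoromethyl of compound 3, would give a step of similar size, or whether this large step is particular to fluoro. They also leave open how compound 4 would read in this assay with an amine or a carboxylic acid in place of its fluoro, which would test whether a low number at this position holds across other groups.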